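The source may hold more compounds than are shown below. What is called first, only, known or untested is meant among the compounds shown, and "the series" means these compounds.

Values in a functional assay on MGC-803 cells (Homo sapiens) for inhibition, read by sulforhodamine B assay; a lower number here means a stronger inhibitor, a higher number a weaker inhibitor:
compound 1, `Cc1ccc(NC2=CC(=O)c3c(nc4n3[C@H]3OC[C@@H](O)[C@H]3OC4)C2=O)cc1C`: 1050 nM
compound 2, `CCCc1ccc(NC2=CC(=O)c3nc4n(c3C2=O)[C@H]2OC[C@@H](O)[C@H]2OC4)cc1`: 1560 nM
compound 3, `O=C1C=C(Nc2ccc(Br)cc2)C(=O)c2c1nc1n2[C@H]2OC[C@@H](O)[C@H]2OC1`: 1010 nM

Compound 1 holds the second highest of the three numbers; its nearest neighbour is compound 3 and its furthest compound 2, and both gaps lie within the scatter. The next compound, compound 4 `O=C1C(Nc2cccc(F)c2)=CC(=O)c2c1nc1n2[C@H]2OC[C@@H](O)[C@H]2OC1`, differs from compound 1 in one place: 3-fluorophenyl in place of 3,4-dimethylphenyl on an amine nitrogen. Among the measured compounds shown here, the only measured step touching the group on the amine nitrogen is a 1.5-fold lower number from compound 2 to compound 3 (0.19 log units; within the scatter), which stays within the scatter, and no step pairs a dimethylphenyl with a fluorophenyl. On that basis compound 4 is expected to sit near compound 1, with a step of a 1.2-fold higher number from compound 1 to compound 4 (0.09 log units; within the scatter), not beyond the scatter. The estimate for compound 4 is 1300 nM, range 500 nM to 3500 nM.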

Compound 4, half-maximal inhibitory concentration: 1470 nM
Compound 4: the middle estimate sits 1.1-fold (0.05 log units) below what was measured; measured number inside the range.
By their numbers in this assay, from the lowest: compounds 3, 1, 4 and 2 (each within the scatter of the next).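

In this assay, the change on the amine nitrogen gives a 1.4-fold higher number from compound 1 to compound 4 (0.15 log units; within the scatter) and stays within the scatter. This position therefore accepts 3-fluorophenyl as well as 3,4-dimethylphenyl, so removing both methyl groups and adding a fluorine leaves the reading unresolved from that of compound 1. No measurement shown here accounts for the size of this step. Still open, from the compounds shown here alone, is whether an amine or a carboxylic acid on the phenyl ring would produce a step beyond the scatter. Also open, going by these compounds, is how a saturated ring such as cyclohexyl would compare on the same nitrogen.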